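From dipropylamino to azepan-1-yl: cytotoxicity at the limit

The source may hold more compounds than are shown below. What is called first, only, known or untested is meant among the compounds shown, and "the series" means these compounds.

In an ADME assay on MT4 cells (Homo sapiens) for cytotoxicity, read by MTT assay, with a stated time of 4 days (a lower number here means that less compound is tolerated, a higher number that more compound is tolerated), compound 3 `CCCN(CCC)c1nc(Cc2c(F)cccc2F)c(C)c(=O)[nH]1` reads > 74000 nM as a limit of the assay and not a number. Compound 2 `CCN(CC)c1nc(Cc2c(F)cccc2F)c(C)c(=O)[nH]1` gives > 81000 nM as a limit too. Compound 1 `O=c1cc(Cc2c(F)cccc2F)nc(N2CCCCCC2)[nH]1`, which also carries azepan-1-yl, gives > 78000 nM as a limit as well. All three results are limits, so none can be ranked against another.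

Compound 4 `Cc1c(Cc2c(F)cccc2F)nc(N2CCCCCC2)[nH]c1=O` has azepan-1-yl in place of the dipropylamino of compound 3, on an aromatic carbon between two ring nitrogen atoms azepan-1-yl in place of dipropylamino on an aromatic carbon and the rest of the structure is unchanged. Going by the values given here, the one measured step at this place is a step that the two limits leave unreadable from compound 2 to compound 3, with dipropylamino in place of diethylamino, so it offers no size to carry over. With compound 3 at > 74000 nM as a limit, no step beyond the scatter is expected in this assay, and no direction can be given. The estimated step is a step that the limit leaves unreadable from compound 3 to compound 4 in size. For compound 4 the estimated value is 80000 nM, with an expected range from 45000 nM to 120000 nM in this assay. The most likely outcome is that the assay again reports only a limit.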

Compound 4, half-maximal cytotoxic concentration: > 75000 nM
Compound 4 was reported as a limit (the forecaster's own chance of this, stated with the estimate: 85%); the middle value is on the limit's open side.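

In this assay compound 4 gives > 75000 nM, which is a limit of the assay and not a number. Going by these compounds alone, compound 1, compound 2 and compound 3 also stand only as limits, so no step to compound 4 can be read. The compounds shown leave open at what concentration any of these four becomes toxic to the cells, and whether swapping the amino groups or adding the methyl changes that concentration.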